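The source may report more compounds than this note shows. Statements on the series, on what has been measured and on what is new or still open speak of the compounds shown alone.

Working notes on the series.

Compound 1 `BrCCCCOc1c(Br)cc(Br)cc1Oc1ccc(Br)cc1Br` is the starting point. In a functional assay on HL-60 cells (Homo sapiens) for cytotoxicity, read by MTT assay, with a stated time of 24 h (on this read-out lower numbers stand for stronger inhibition and higher numbers for weaker inhibition), compound 1 gives 25.9 ug/mL, the lowest of the three numbers in hand, though its gaps to the other two stay within the scatter. Compound 2 `BrCCCCCCOc1c(Br)cc(Br)cc1Oc1ccc(Br)cc1Br` gives 37.8 ug/mL in this assay, and compound 3 `CC(=O)Oc1c(Br)cc(Br)cc1Oc1ccc(Br)cc1Br` gives 29.9 ug/mL in this assay.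

The step to compound 4 `OCCOc1c(Br)cc(Br)cc1Oc1ccc(Br)cc1Br` is hydroxy in place of 2-bromoethyl on a saturated chain carbon, two bonds along the chain from an oxygen on an aromatic ring.

Going by the values given here, two measured steps bear on this. Changing the end of the chain on the oxygen gave a 1.5-fold higher number from compound 1 to compound 2 (0.16 log units; within the scatter). Replacing the whole 4-bromobutyl group on the oxygen with acetyl gave a 1.2-fold higher number from compound 1 to compound 3 (0.06 log units; within the scatter). Neither alteration at this oxygen moved the read-out beyond the scatter, so the expected step for compound 4 in this assay is none beyond the scatter, in no clear direction, as a 1.2-fold higher number from compound 1 to compound 4 (0.06 log units; within the scatter).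

Compound 4 is therefore estimated at 30 ug/mL in this assay, within a range of 12 ug/mL to 75 ug/mL.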

Compound 4, half-maximal inhibitory concentration: 28.2 ug/mL
Estimate against measurement, compound 4: 1.1-fold (0.03 log units) above; low and high end bracket the measured number.
By their numbers in this assay, from the lowest: compounds 1, 4, 3 and 2 (each within the scatter of the next).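

In this assay, the exchange of 4-bromobutyl for 2-hydroxyethyl on this oxygen stays within the scatter, with a 1.1-fold higher number from compound 1 to compound 4 (0.04 log units; within the scatter). The comparisons with the other two groups on this oxygen also stay within the scatter, with a 1.1-fold lower number from compound 3 to compound 4 (0.03 log units; within the scatter) and a 1.3-fold lower number from compound 2 to compound 4 (0.13 log units; within the scatter), so this position now also accepts a chain ending in hydroxy, with a hydrogen-bond donor and acceptor that the bromo-ended chain lacks, without a step beyond the scatter. No measurement is at hand that would explain this flat result.

As far as these compounds go, whether any group on this oxygen can move the read-out beyond the scatter remains open. A chain ending in an amine or a carboxylic acid, or a chain longer than 6-bromohexyl, would test this.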